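This account rests on a few compounds, and the source may have more. Where it says the series, first, only, none or still open, it means among the compounds named here.

Measured in an ADME assay for permeability; a lower number here means that the compound crosses the layer more slowly, a higher number that the compound crosses the layer faster:
compound 1 `CNC(=O)c1cc(C(=O)N[C@H]2CC[C@H](O)CC2)c([C@@H](C)c2ccc(Cl)cc2)o1` gives 150 nm/s
compound 2 `CNC(=O)c1cc(C(=O)NC2CC2)cn([C@@H](C)c2ccccc2)c1=O` gives 16 nm/s

Of these two, compound 1 gives the higher number in this assay, and compound 2 sits well below it; the gap between them lies beyond the usual scatter. The two structures differ in several places at once, so their gap cannot be tied to any single change.

Compound 3 `CNC(=O)c1cc(C(=O)N[C@H]2CC[C@H](O)CC2)c([C@@H](C)c2ccccc2)o1` is an unmeasured analogue of compound 1. It differs from compound 1 by hydrogen in place of chloro on an aromatic carbon. Among the measured compounds shown here, nothing among the measured pair isolates this change, so the expectation rests on the small size of the change alone. For the step from compound 1 to compound 3 in this assay a modest fall is expected, one that may not exceed the scatter, a 1.4-fold lower number from compound 1 to compound 3 (0.13 log units; within the scatter). Compound 3 is therefore estimated at 110 nm/s, within a range of 55 nm/s to 220 nm/s.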

Compound 3, apparent permeability: 42 nm/s
Beside the measured number, compound 3's estimate is 2.6-fold (0.42 log units) above it; the measured number lies below the stated range.
By their numbers in this assay, from the lowest: compound 2; then compound 3; then compound 1.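

In this assay, among the compounds shown here, the change from 4-chlorophenyl to phenyl is the first comparison in this set that differs in one place only, and it gives a 3.6-fold lower number from compound 1 to compound 3 (0.55 log units; beyond the scatter) as its step. The chloro on this six-membered aromatic ring, para to a large group, therefore matters to this read-out: exchanging that single heavy atom for hydrogen, with no hydrogen-bond donor, hydrogen-bond acceptor or net charge entering or leaving, moves the number beyond the scatter. Nothing at hand accounts for the size of this step.

From the compounds shown here alone, whether fluoro, methoxy or a nitrile on the same carbon would give a number nearer that of compound 1 or that of compound 3 remains open. Also open, going by these compounds, is whether the same step would appear on the core of compound 2, which carries a plain phenyl.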